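The source may report more compounds than this note shows. Statements on the series, on what has been measured and on what is new or still open speak of the compounds shown alone.

Working notes on the series. In an ADME assay on HEK293 cells (Homo sapiens) for cytotoxicity, read by MTT assay, with a stated time of 24 h (a lower number here means a stronger inhibitor, a higher number a weaker inhibitor), compound 1 (`CN1CCN(c2nc3cc([N+](=O)[O-])ccc3nc2NCc2ccc(C(F)(F)F)cc2)CC1`) gives 6.99 ug/mL and compound 2 (`CN(C)CCCNc1nc2cc([N+](=O)[O-])ccc2nc1NCc1ccc(Br)cc1`) gives 9.63 ug/mL so compound 2 stands level with compound 1 within the scatter. Among the measured compounds shown here, no step between measured compounds that differ in one place is available. The move to compound 3 (`Cc1ccccc1CNc1nc2ccc([N+](=O)[O-])cc2nc1NCCCN(C)C`) is 2-methylphenyl in place of 4-bromophenyl on a saturated chain carbon bound to a nitrogen on an aromatic ring and puts 2-methylphenyl in place of 4-bromophenyl on a saturated chain carbon bound to a nitrogen on an aromatic ring. The expected 1.0-fold lower number from compound 2 to compound 3 (0.01 log units; within the scatter) in this assay stays within the scatter and has no expected direction. For compound 3 the estimated value is 9.5 ug/mL with 4 ug/mL as the expected lower end and 22 ug/mL as the upper end.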

Compound 3, half-maximal inhibitory concentration: 27.6 ug/mL
For compound 3 the middle estimate is 2.9-fold (0.46 log units) below the measured one; the measured number lies above the stated range.
By their numbers in this assay, from the lowest: compounds 1 and 2 (each within the scatter of the next); then compound 3.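

In this assay, 2-methylphenyl in place of 4-bromophenyl on a saturated chain carbon bound to a nitrogen on an aromatic ring gives a 2.9-fold higher number from compound 2 to compound 3 (0.46 log units; beyond the scatter) and thus a weaker inhibitor. Among the compounds shown here, this is the first step, and it shows that the number responds to this aryl change, though only modestly. Nothing measured bears on the cause of this step.

For the compounds shown here, the single step leaves open whether losing the bromine or gaining the methyl carries the change. A 4-methylphenyl or 2-bromophenyl group at this place would separate the two.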